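Shortening the Long Chain on a Rearranged Core

The source may report more compounds than this note shows. Statements on the series, on what has been measured and on what is new or still open speak of the compounds shown alone.

Measured compounds:
- compound 1, `CCCCCCCCCCCCCCCCc1c(C)c(N(C)C)nc(C)c1O`: 91%
- compound 2, `CCCCCCCCCCCCCCCCCCCc1c(C)c(N(C)C)nc(C)c1O`: 64%
- compound 3, `CCCCCCCCCCCCCCCCCCCc1nc(N(C)C)c(C)c(C)c1O`: 65%

All three compounds were tested in a functional assay on cells (Lymphocyte, Homo sapiens) for inhibition, read by flow cytometry, using a membrane potential dye, with a stated time of 16 h, tested at 500 nM; on this read-out lower numbers stand for a weaker effect and higher numbers for a stronger effect at the one concentration tested. Compound 1 is the shortest of the three, and in this assay compound 1 gives 91%. Compound 2 carries a longer saturated chain, and compound 2 gives 64%. The change between them is hydrogen in place of propyl on a saturated chain carbon, ten or more bonds along the chain from an aromatic carbon, and the step it made is a number 27 percentage points higher from compound 2 to compound 1 (beyond the scatter).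

Compound 3 is built from the same atoms as compound 2, joined differently; the difference between the two cores is not broken down here. In this assay compound 3 gives 65%, which sits within the scatter of compound 2, so the two are not told apart.

Compound 4, `CCCCCCCCCCCCCCCCc1nc(N(C)C)c(C)c(C)c1O`, has not yet been measured. It stands to compound 3 as compound 1 stands to compound 2: the change is hydrogen in place of propyl on a saturated chain carbon, ten or more bonds along the chain from an aromatic carbon. The place of the change is described in the same words for both pairs, so this is the same kind of change made on a different core. Because compound 2 to compound 1 gave a number 27 percentage points higher from compound 2 to compound 1 (beyond the scatter), a step of similar direction is expected here, though its size on the rearranged core is uncertain; the step expected from compound 3 to compound 4 is a number 19 percentage points higher from compound 3 to compound 4 (beyond the scatter). Compound 4 is therefore estimated at 84%, with a likely range from 68% to 97%.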

Compound 4, a percentage reported as activity, at one concentration (the size of the read-out at that concentration, not a potency): 92%
Estimate against measurement, compound 4: 8 percentage points below; measured number inside the range.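

In this assay, putting hydrogen in place of propyl on a saturated chain carbon, ten or more bonds along the chain from an aromatic carbon, gives a number 27 percentage points higher from compound 3 to compound 4 (beyond the scatter). The shortening therefore carried over from one core to the other, in the same direction and with a size that the two cores do not tell apart: the same change on two cores in this assay, a number 27 percentage points higher (beyond the scatter) from compound 2 to compound 1 and a number 27 percentage points higher (beyond the scatter) from compound 3 to compound 4, 0 percentage points apart, within the scatter of two such steps This agreement rests on just two matched pairs, one kind of change and a single tested concentration, so it does not show that the step would keep its size on any further core, and it speaks only of a stronger effect at that one concentration, not of why the shorter chain reads higher.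

The compounds shown stop at two chain lengths, so it remains open whether the read-out keeps rising as the chain is shortened further, for instance to an octyl chain, and whether the two cores would still match at that length. Also open is how either core would respond to a chain that is branched or ends in an amine or a carboxylic acid, since the chains shown here are all straight and carry no such group.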